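Swapping the Aryl Group on a Weakly Active Core

The source may report more compounds than this note shows. Statements on the series, on what has been measured and on what is new or still open speak of the compounds shown alone.

Of the compounds shown here, three have been measured in a functional assay on MCF7 cells (Homo sapiens) for cytotoxicity, read by MTT assay, with a stated time of 72 h; a lower number here means a stronger inhibitor, a higher number a weaker inhibitor.

Compound 1: `Cc1cc(=O)n(-c2ccccc2C(F)(F)F)nc1C(=O)Nc1ccc(Oc2ncnc3ccsc23)cc1` gives 5550 nM.
Compound 2: `Cc1ccc(-n2nc(C(=O)Nc3ccc(Oc4ncnc5ccsc45)c(F)c3)c(C)cc2=O)cc1` gives 7250 nM.
Compound 3: `Cc1cc(=O)n(-c2ccccc2C(F)(F)F)nc1C(=O)Nc1ccc(Oc2ncnc3sccc23)cc1` gives > 40000 nM.

Compound 1 and compound 3 differ only in the group on the ether oxygen, and that exchange gave an at least 7.2-fold higher number from compound 1 to compound 3 (0.85 log units; beyond the scatter). Compound 3 thus sits at the limit of this assay, (the limit of > 40000 nM in this assay, at which 1 of the 3 values shown sits). Its standing among the three is therefore not a number but a ceiling.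

Compound 4, `Cc1cc(=O)n(-c2ccc(F)cc2)nc1C(=O)Nc1ccc(Oc2ncnc3sccc23)cc1`, keeps the core of compound 3 and differs from it by 4-fluorophenyl in place of 2-(trifluoromethyl)phenyl on an aromatic nitrogen. For the measured compounds named here, no measured step bears on this change: the one measured step, from compound 1 to compound 3, alters the ether side, and compound 2 differs from the others in more than one place, so its value alone cannot be separated into the effect of the aryl group on the nitrogen. With compound 3 at the limit, there is no anchor above which a shift could be read.

Compound 4 is therefore expected to remain weak in this assay, with an estimated value of 30000 nM and a range from 8000 nM to 90000 nM. The expected step is an at least 1.3-fold lower number from compound 3 to compound 4 (0.12 log units; that floor lies within the scatter), and a further limit rather than a number is quite possible.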

Compound 4, half-maximal inhibitory concentration: 21000 nM
Beside the measured number, compound 4's estimate is 1.4-fold (0.15 log units) above it; measured number inside the range.
By their numbers in this assay, from the lowest: compounds 1 and 2 (each within the scatter of the next); then compound 4. At a limit, above all of these: compound 3.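

For the compounds shown here, the exchange of 2-(trifluoromethyl)phenyl for 4-fluorophenyl on the aromatic nitrogen provides the only step that bears on this position, and in this assay it reads as an at least 1.9-fold lower number from compound 3 to compound 4 (0.27 log units; that floor lies within the scatter). This shows that the core of compound 3, with its ether side left unchanged, can give a measured number once this aryl group is exchanged, although the floor of the step does not by itself establish a change beyond the scatter. The true size of the step stays unknown, since the starting point is a limit and not a number: the limit of > 40000 nM in this assay, at which 1 of the 4 values shown sits.

The compounds shown leave open whether the same exchange on the aromatic nitrogen would shift the number when the ether side of compound 1 is present, and so whether the effect of this position depends on the group on the ether oxygen. They also leave open how this position would respond to an aryl group carrying something other than fluorine or trifluoromethyl, such as a methoxy group, an amine or a carboxylic acid, or to a pyridine ring in place of the phenyl ring.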